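This account rests on a few compounds, and the source may have more. Where it says the series, first, only, none or still open, it means among the compounds named here.

Of the compounds shown here, two have been measured so far in an assay for inhibition of Tryptophan 2,3-dioxygenase (Homo sapiens), with stated times of 10 min and 60 min, tested at 10 uM; on this read-out lower numbers stand for a weaker effect and higher numbers for a stronger effect at the one concentration tested. Compound 1 `O=[N+]([O-])c1ccccc1CNc1cc(Br)cc2cn[nH]c12` gives 35% in this assay, and compound 2 `Nc1cccc(CNc2cc(C(F)(F)F)cc3[nH]ncc23)c1` gives 68%. Compound 2 therefore stands highest of the two numbers, and its nearest neighbour, compound 1, lies lower by a margin beyond the usual scatter. Compound 3 `Oc1ccc(CNc2cc(C(F)(F)F)cc3[nH]ncc23)cc1` has not yet been measured. It differs from compound 2 in one place: 4-hydroxyphenyl in place of 3-aminophenyl on a saturated chain carbon bound to a nitrogen on an aromatic ring. Among the compounds with values here, no measured pair shows this exchange, so its size in this assay cannot be read from the data; a shift in either direction is possible, and an outcome within the scatter of compound 2 cannot be excluded. Given only the value of compound 2, compound 3 is expected to land near 55%, within a range from 25% to 80%. The estimated step is a number 13 percentage points lower from compound 2 to compound 3 (beyond the scatter).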

Compound 3, a percentage reported as inhibition, at one concentration (the size of the read-out at that concentration, not a potency): 75%
The estimate for compound 3 lay 20 percentage points below the measured number; measured number inside the range.
By their numbers in this assay, from the lowest: compound 1; then compounds 2 and 3 (each within the scatter of the next).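

In this assay, 4-hydroxyphenyl in place of 3-aminophenyl on a saturated chain carbon bound to a nitrogen on an aromatic ring gives a number 7 percentage points higher from compound 2 to compound 3 (within the scatter). Within the data shown here, this is the first direct reading at this place: the two groups, each with 7 heavy atoms, 1 hydrogen-bond donor and 1 hydrogen-bond acceptor, are not separated by this read-out. Nothing measured alongside these numbers offers an explanation for this result.

Compound 1 differs from compound 2 and compound 3 in more than one place, so the share of each of its differences cannot be read. The compounds shown also leave open how a plain phenyl, a carboxylic acid or a longer chain would read at this place.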